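The source may report more compounds than this note shows. Statements on the series, on what has been measured and on what is new or still open speak of the compounds shown alone.

Of the compounds shown here, two share one core and have been tested in a functional assay on MCF7 cells (Homo sapiens) for inhibition, read by MTT assay, with a stated time of 72 h; a higher number here means a weaker inhibitor, a lower number a stronger inhibitor. Compound 1, `CN(C(=O)NC(=O)c1ccc(F)c(F)c1)c1nc(C(F)(F)F)c(C(=O)N/N=C/c2ccccc2C(F)(F)F)s1`, gives 8.21 ug/mL in this assay. Compound 2, `CN(C(=O)NC(=O)c1c(F)cccc1F)c1nc(C(F)(F)F)c(C(=O)N/N=C/c2ccc(C(F)(F)F)cc2)s1`, gives 35.3 ug/mL in this assay, the highest of the two numbers; its nearest neighbour is compound 1, a gap beyond the scatter. Compound 3, `CN(C(=O)NC(=O)c1c(F)cccc1F)c1nc(C(F)(F)F)c(C(=O)N/N=C/c2ccccc2C(F)(F)F)s1`, is the next compound and has not yet been measured. Going by the values given here, the change from compound 2 to compound 3 is 2-(trifluoromethyl)phenyl in place of 4-(trifluoromethyl)phenyl on a carbon with a double bond to nitrogen: the same atoms, joined differently, so the 2-(trifluoromethyl)phenyl group that compound 3 carries is the one already present in compound 1. Among the compounds with values here, no step between measured compounds isolates this change, so its size is uncertain; a modest move toward a lower number is expected, a 2.4-fold lower number from compound 2 to compound 3 (0.37 log units; beyond the scatter), resting on compound 1 with its 8.21 ug/mL. Compound 3 is therefore estimated at 15 ug/mL in this assay, within a range from 6 ug/mL to 40 ug/mL.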

Compound 3, half-maximal inhibitory concentration: 20.4 ug/mL
Compound 3: the middle estimate sits 1.4-fold (0.13 log units) below what was measured; measured number inside the range.
By their numbers in this assay, from the lowest: compound 1; then compounds 3 and 2 (each within the scatter of the next).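

Placing the trifluoromethyl group differently on the phenyl ring, 2-(trifluoromethyl)phenyl in place of 4-(trifluoromethyl)phenyl on a carbon with a double bond to nitrogen, gives a 1.7-fold lower number from compound 2 to compound 3 (0.24 log units; within the scatter) in this assay, so this swap of otherwise identical atoms cannot be told apart from repeat-measurement noise. The other single-place change, 2,6-difluorophenyl in place of 3,4-difluorophenyl on a carbonyl carbon, gives a 2.5-fold higher number from compound 1 to compound 3 (0.40 log units; beyond the scatter), a step that does stand clear of that noise. No measurement shown explains either step.

Still open, as far as these compounds go, is whether 3,4-difluorophenyl would give the same result when paired with 4-(trifluoromethyl)phenyl. Also open, from the compounds shown here alone, is whether a phenyl ring carrying an amine or a carboxylic acid in place of trifluoromethyl would move the number beyond the scatter.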